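A few compounds are considered here, and "the series" means these few. Any claim that something is new, unique, unknown or untested is made for them only; others in the source may bear on it.

Measured compounds:
compound 1, `Cc1n[nH]cc1-c1cc2c(s1)C(=O)N[C@]1(CC[C@@](O)(c3ccc(F)cc3)CC1)N2`, in an assay for inhibition of Rho-associated protein kinase 1 (Homo sapiens), read by TR-FRET, with stated times of 5 min and 2 h (on this read-out lower numbers stand for stronger inhibition and higher numbers for weaker inhibition), compound 1 gives 130 nM
compound 2, `CCCC1(C)NC(=O)c2sc(-c3ccncc3)cc2N1`, in this assay compound 2 gives 33 nM
compound 3, `Cc1n[nH]cc1-c1cc2c(s1)C(=O)N[C@]1(CC[C@](O)(c3ccc(F)cc3)CC1)N2`, in this assay compound 3 gives 820 nM

Compound 2 stands lowest of the three numbers in this assay; compound 1 is its nearest neighbour and compound 3 the furthest, both beyond the scatter. For the measured compounds named here, the only step measured between single-change neighbours is a 6.3-fold higher number from compound 1 to compound 3 (0.80 log units; beyond the scatter), and it rests on the fact that compounds 1 and 3 differ only in the configuration as drawn: the two compounds are mirror images and differ in nothing else.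

Compound 4, `CC1(CC(F)(F)F)NC(=O)c2sc(-c3ccncc3)cc2N1`, differs from compound 2 by trifluoromethyl in place of ethyl on a saturated chain carbon bound to a saturated ring carbon. Going by the values given here, no measured step in this assay concerns such a change to the chain on the saturated ring carbon; the one step available speaks only of configuration and therefore gives no guidance on size or direction here. With nothing shown that would move the number, the step of a 1.5-fold higher number from compound 2 to compound 4 (0.18 log units; within the scatter) is expected to stay within the scatter, with the uncertainty widened for an untested change. Compound 4 is therefore expected to give 50 nM, in a range from 15 nM to 170 nM.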

Compound 4, half-maximal inhibitory concentration: 31 nM
Compound 4: the middle estimate sits 1.6-fold (0.21 log units) above what was measured; low and high end bracket the measured number.
By their numbers in this assay, from the lowest: compounds 4 and 2 (each within the scatter of the next); then compound 1; then compound 3.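

In this assay, the chain on the saturated ring carbon gives its first measured single change, and that change does not move the number beyond the scatter: a 1.1-fold lower number from compound 2 to compound 4 (0.03 log units; within the scatter). For this one pair, then, trifluoromethyl can stand in place of ethyl on a saturated chain carbon bound to a saturated ring carbon with the two numbers remaining indistinguishable. The one available structural fact concerns configuration in a different pair and does not bear on this change, so the result comes with no explanation.

Going by these compounds, whether an amine, a carboxylic acid or a longer chain at this place would also leave the number within the scatter remains open. On these data alone, the saturated ring carbon carrying the chain is drawn without configuration in compound 2 and compound 4, so how its two mirror forms would compare in this assay is also open.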